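Swapping a Dimethoxyphenyl for a Fluorophenyl on the Shared Core

The source may report more compounds than this note shows. Statements on the series, on what has been measured and on what is new or still open speak of the compounds shown alone.

Compound 2 `COc1ccc(CNc2nc3cc(N)cc(N)c3nc2-c2ccccc2)cc1OC` carries a 3,4-dimethoxyphenyl group on a saturated chain carbon bound to a nitrogen on an aromatic ring. In a functional assay on A549 cells (Homo sapiens) for inhibition, read by sulforhodamine B assay, with a stated time of 48 h (a higher number here means that more compound is tolerated, a lower number that less compound is tolerated), compound 2 gives < 100000 nM, which is a limit of the measurement rather than a number. Compound 1 `Nc1cc(N)c2nc(-c3ccccc3)c(Oc3ccc(Cl)c(Cl)c3)nc2c1` is the other measured compound, and in this assay compound 1 also gives < 100000 nM, again a limit. Both results therefore sit at the limit of < 100000 nM in this assay, at which 2 of the 2 values shown sit, so the available numbers do not rank compound 1 and compound 2 against each other. Compound 3 `Nc1cc(N)c2nc(-c3ccccc3)c(NCc3ccc(F)cc3)nc2c1` is not yet measured and differs from compound 2 by 4-fluorophenyl in place of 3,4-dimethoxyphenyl on a saturated chain carbon bound to a nitrogen on an aromatic ring. For the measured compounds named here, no measured pair shows the effect of such a swap, and with both known values at a limit no direction can be read from them. The step from compound 2 to compound 3 is expected to be a step that the limit leaves unreadable from compound 2 to compound 3, no change beyond scatter. Compound 3 is expected to give 30000 nM, within 5000 nM to 100000 nM, quite possibly again reported only as a limit.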

Compound 3, concentration lethal to 50% of the cells: 69200 nM
Estimate against measurement, compound 3: 2.3-fold (0.36 log units) below; the measured number falls inside the stated range.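

For the compounds shown here, neither the step from compound 2 to compound 3 nor the one from compound 1 to compound 3 can be read, because compound 1 and compound 2 each give only a limit: the limit of < 100000 nM in this assay, at which 2 of the 3 values shown sit. The compounds shown leave open whether 4-fluorophenyl in place of 3,4-dimethoxyphenyl changes the result at all.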